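This account rests on a few compounds, and the source may have more. Where it says the series, first, only, none or still open, it means among the compounds named here.

Compound 1 `Nc1nc(N)c2c(-c3cccs3)cn([C@@H]3O[C@H](CO)[C@@H](O)[C@H]3O)c2n1`: > 20000 nM
Compound 2 `Nc1nc(N)c2c(-c3cc4ccccc4o3)cn([C@@H]3O[C@H](CO)[C@@H](O)[C@H]3O)c2n1`: 14000 nM
Compound 3 `Cc1nc(N)c2c(-c3cc4ccccc4o3)cn([C@@H]3O[C@H](CO)[C@@H](O)[C@H]3O)c2n1`: 13100 nM

In a functional assay on HCT-116 cells (Homo sapiens), read by MTT assay, with a stated time of 72 h (on this read-out lower numbers stand for stronger inhibition and higher numbers for weaker inhibition), compound 2 gives 14000 nM, and compound 3, at 13100 nM, lies within the scatter of it. Compound 1 gives only a limit of the assay, > 20000 nM, not a number.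

Compound 4 `COc1nc(N)nc2c1c(-c1cc3ccccc3o1)cn2[C@@H]1O[C@H](CO)[C@@H](O)[C@H]1O` keeps the rest of compound 2 but has methoxy in place of amino on an aromatic carbon.

The closest measured change is a 1.1-fold lower number from compound 2 to compound 3 (0.03 log units; within the scatter). That change also removes an amino group, but it is the other amino group of compound 2, so it is only a loose guide. The change an at least 1.4-fold lower number from compound 1 to compound 2 (0.15 log units; that floor lies within the scatter) concerns a different group and says little here.

With one small related step to go on, no shift beyond the scatter is expected in this assay. What is expected is a 1.3-fold lower number from compound 2 to compound 4 (0.10 log units; within the scatter). Compound 4 is estimated at 11000 nM, with an expected range of 3500 nM to 20000 nM.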

Compound 4, half-maximal inhibitory concentration: > 20000 nM
Compound 4 ended at the assay's limit; the forecaster's own chance of this, stated with the estimate: 30%; at least 1.8-fold (0.25 log units) between middle value and limit.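

In this assay, methoxy in place of amino at this position gives an at least 1.4-fold higher number from compound 2 to compound 4 (0.15 log units; that floor lies within the scatter). Compound 4 gives > 20000 nM, which is a limit of the assay and not a number, so the full size of the step cannot be read. The earlier change at the other amino group, a 1.1-fold lower number from compound 2 to compound 3 (0.03 log units; within the scatter), still ended in a measured number, whereas this change, on the carbon next to the ring nitrogen, ends at the limit, which leaves the result short of a firm comparison: the limit of > 20000 nM in this assay, at which 2 of the 4 values shown sit.

The compounds shown cannot separate what leaving amino does from what entering methoxy does at this position. A hydroxyl group, a methylamino group or a plain methyl group on this same carbon would help to tell these two apart.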